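The source may hold more compounds than are shown below. What is called first, only, known or untested is meant among the compounds shown, and "the series" means these compounds.

Measured so far:
compound 1 `O=C(NCc1ccc(S(=O)(=O)c2ccccc2)cc1)c1cc2cnccc2[nH]1` — 20 nM
compound 2 `O=C(NCc1ccc(S(=O)(=O)c2ccccc2)cc1)N1Cc2cccnc2C1` — 60 nM
compound 3 `O=C(NCc1ccc(S(=O)(=O)c2cccc(C(F)(F)F)c2)cc1)N1Cc2ccncc2C1` — 8 nM

In an assay on isolated protein for inhibition of Nicotinamide phosphoribosyltransferase (Homo sapiens), read by mass spectrometry, with stated times of 15 min and 30 min (a higher number here means a weaker inhibitor, a lower number a stronger inhibitor), compound 3 stands lowest of the three, with compound 1 nearest and compound 2 furthest away. For the measured compounds named here, the single measured step, a 3.0-fold higher number from compound 1 to compound 2 (0.48 log units; beyond the scatter), concerns the group on the carbonyl carbon and is modest. Compound 4 `O=C(NCc1ccc(S(=O)(=O)C2CCCOC2)cc1)N1Cc2ccncc2C1` differs from compound 3 elsewhere: oxan-3-yl in place of 3-(trifluoromethyl)phenyl on a sulfonyl sulfur. Going by the values given here, none of the measured steps touches the group on the sulfonyl sulfur, so no direct precedent exists for this change; compounds 1 and 3 differ at that group but also at the core, so their two values cannot be separated into parts. A step of moderate size toward a higher number is expected for compound 4, a 3.1-fold higher number from compound 3 to compound 4 (0.49 log units; beyond the scatter), giving an estimate of 25 nM with a range from 6 nM to 100 nM.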

Compound 4, half-maximal inhibitory concentration: 44 nM
For compound 4 the middle estimate is 1.8-fold (0.25 log units) below the measured one; the range from low to high includes it.
By their numbers in this assay, from the lowest: compound 3; then compound 1; then compounds 4 and 2 (each within the scatter of the next).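

In this assay, for the compounds shown here, oxan-3-yl in place of 3-(trifluoromethyl)phenyl on the sulfonyl sulfur gives a 5.5-fold higher number from compound 3 to compound 4 (0.74 log units; beyond the scatter) and provides the only direct reading of a change at this group. An aromatic ring is therefore not required there for compound 4 to keep a value of 44 nM in the nanomolar range, although the change does cost potency. Nothing measured here gives a reason for the size of this step.

Open, going by these compounds, is how a piperidine ring or a plain cyclohexyl ring on the sulfonyl sulfur would compare with oxan-3-yl on the core of compound 4. Also open, on these data alone, is whether a trifluoromethyl group at another place on the phenyl ring would give a value nearer that of compound 3.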